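This account rests on a few compounds, and the source may have more. Where it says the series, first, only, none or still open, it means among the compounds named here.

Measured compounds in an ADME assay on microsomes from liver (Homo sapiens) for metabolic stability, read by LC-MS, with a stated time of 10 min, tested at 0.5 uM; on this read-out higher numbers stand for a more stable compound and lower numbers for a less stable compound:

compound 1 `c1ccc2c(c1)CN[C@@H](CN(CC1CCNCC1)[C@H]1CCCc3cccnc31)C2`: 86%
compound 2 `c1ccc2c(c1)CN[C@@H](CN(CCN1CCNCC1)[C@H]1CCCc3cccnc31)C2`: 96%
compound 3 `c1ccc2c(c1)CN[C@@H](CN(CCC1CCNCC1)[C@H]1CCCc3cccnc31)C2`: 66%

Compound 3 stands lowest of the three in this assay. Against compound 2 the gap is a number 30 percentage points lower from compound 2 to compound 3 (beyond the scatter), against compound 1 it is a number 20 percentage points lower from compound 1 to compound 3 (beyond the scatter); both lie beyond the scatter. Compound 1 and compound 2 are not separated, since a number 10 percentage points higher from compound 1 to compound 2 (within the scatter) stays within the scatter.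

Compound 4 `c1ccc2c(c1)CN[C@@H](CN(CCCN1CCN(C3CC3)CC1)[C@H]1CCCc3cccnc31)C2` differs from compound 3 in one place: (4-cyclopropylpiperazin-1-yl)methyl in place of piperidin-4-yl on a saturated chain carbon, two bonds along the chain from an amine nitrogen.

The step from compound 2 to compound 3 bears most directly on this, as it swaps the same two ring types at the same place and was beyond the scatter a number 30 percentage points lower from compound 2 to compound 3 (beyond the scatter); compound 4 reverses that swap, so a rise of comparable size toward the level of compound 2 is expected. The step of a number 10 percentage points higher from compound 1 to compound 2 (within the scatter) points the same way but was within the scatter. Among the compounds with values here, no measured compound carries a cyclopropyl group, so the added portion of the entering group has no precedent here, and the range is kept wide. For compound 4 a step of a number 19 percentage points higher from compound 3 to compound 4 (beyond the scatter) is expected in this assay, giving an estimated 85% with a range from 65% to 98%.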

Compound 4, percent of the compound remaining: 21%
Beside the measured number, compound 4's estimate is 64 percentage points above it, and the stated range ends above it.
By their numbers in this assay, from the lowest: compound 4; then compound 3; then compounds 1 and 2 (each within the scatter of the next).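

In this assay, within the data shown here, the (4-cyclopropylpiperazin-1-yl)methyl group gives a number 45 percentage points lower from compound 3 to compound 4 (beyond the scatter) and a number 75 percentage points lower from compound 2 to compound 4 (beyond the scatter) and also a number 65 percentage points lower from compound 1 to compound 4 (beyond the scatter) as the largest steps, so this part of the molecule can move the read-out much further than the earlier compounds showed. Compound 2 and compound 4 both carry a six-membered non-aromatic ring with 2 hetero atoms, yet they stand at opposite ends of the series, so the presence of that ring alone does not set the number here; the earlier link between this ring and a high number rested on compound 2 only. Nothing measured here accounts for a fall of this size or places it on one part of the entering group.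

Still open, as far as these compounds go, is how much of the fall belongs to the cyclopropyl group and how much to the added chain length. A methyl or an acetyl group in place of the cyclopropyl group, or the same cyclopropyl-bearing ring on the chain of compound 2, would bear on that split.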